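Amidine in Place of Aminomethyl: Expected Hydrolase Inhibition

A few compounds are considered here, and "the series" means these few. Any claim that something is new, unique, unknown or untested is made for them only; others in the source may bear on it.

Measured compounds:
- compound 1 `Cn1nc2c(=O)n(CC3(O)CCN(Cc4ccc(-c5ccco5)cc4Cl)CC3)cnc2c1-c1ccc(F)cc1` — 64.5 nM
- compound 2 `Cn1nc2c(=O)n(CC3(O)CCN(Cc4ccc(-c5ccco5)cc4Cl)CC3)cnc2c1-c1ccc(OC(F)F)cc1` — 179 nM
- compound 3 `CCNCc1ccc(-c2c3ncn(CC4(O)CCN(Cc5ccc(-c6ccco6)cc5Cl)CC4)c(=O)c3nn2C)cc1` — 15.2 nM

All three compounds were tested in an assay on isolated protein for inhibition of ubiquitin carboxyl-terminal hydrolase 7 (Homo sapiens), with stated times of 30 min and 2 h; on this read-out higher numbers stand for weaker inhibition and lower numbers for stronger inhibition. Compound 3 gives the lowest number of the three: compound 1 sits a 4.2-fold lower number from compound 1 to compound 3 (0.63 log units; beyond the scatter) away from it, and compound 2 is the furthest, with a 12-fold lower number from compound 2 to compound 3 (1.07 log units; beyond the scatter). The two substituents on the outer aromatic ring of compounds 1 and 2 differ by a 2.8-fold higher number from compound 1 to compound 2 (0.44 log units; beyond the scatter).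

Compound 4 `Cn1nc2c(=O)n(CC3(O)CCN(Cc4ccc(-c5ccco5)cc4Cl)CC3)cnc2c1-c1ccc(C(=N)N)cc1` is not yet measured. It differs from compound 3 in one place: a group of 3 heavy atoms (1 carbon, 2 nitrogen; no ring) in place of a group of 4 heavy atoms (3 carbon, 1 nitrogen; no ring), on an aromatic carbon. Within the data shown here, no measured step exchanges these two groups directly. The step that bears most closely on it is a 4.2-fold lower number from compound 1 to compound 3 (0.63 log units; beyond the scatter), which shows that a nitrogen-bearing group at this place gives a lower number than fluoro. Compound 4 keeps a nitrogen-bearing group here, so no large move is expected in either direction; a modest step toward a higher number, near the scatter, is the estimate, a 2.0-fold higher number from compound 3 to compound 4 (0.30 log units; within the scatter). Compound 4 is therefore expected to give about 30 nM, within 8 nM to 110 nM.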

Compound 4, half-maximal inhibitory concentration: 87.5 nM
Beside the measured number, compound 4's estimate is 2.9-fold (0.46 log units) below it; the measured number falls inside the stated range.
By their numbers in this assay, from the lowest: compound 3; then compounds 1 and 4 (each within the scatter of the next); then compound 2.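

Carrying nitrogen at this place does not by itself keep the lower number in this assay: the amidine of compound 4 loses the gain held by (ethylamino)methyl, with a 5.8-fold higher number from compound 3 to compound 4 (0.76 log units; beyond the scatter) as the step. The amidine is also no real gain over fluoro, since a 1.4-fold higher number from compound 1 to compound 4 (0.13 log units; within the scatter) is a step that stays within the scatter, although it does still improve on difluoromethoxy, with a 2.0-fold lower number from compound 2 to compound 4 (0.31 log units; beyond the scatter) as the step. So the identity of the nitrogen-bearing group matters here, but nothing available explains why these two groups differ.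

The compounds shown do not separate the role of the ethyl group from that of the carbon chain linking the nitrogen to the ring. A plain aminomethyl group or a longer chain such as (propylamino)methyl would test that, and a carboxylic acid would show how a nitrogen-free group with oxygen atoms fares at this place.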